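A few compounds are considered here, and "the series" means these few. Any claim that something is new, unique, unknown or untested is made for them only; others in the source may bear on it.

In a functional assay on A549 cells (Homo sapiens) for antiproliferative activity, read by MTT assay, with a stated time of 48 h, in the presence of a further agent that is not named here (a lower number here means a stronger inhibitor of growth, a higher number a weaker inhibitor of growth), the measured members of the series read:

compound 1 `O=C(NOCc1ccccc1F)c1cn(-c2ccccc2)nc1-c1ccccc1`: 5940 nM
compound 2 `Cc1ccc(-c2nn(-c3ccccc3)cc2C(=O)NOCc2ccccc2F)cc1`: 260 nM
compound 3 `O=C(NOCc1ccccc1F)c1cn(-c2ccccc2)nc1-c1ccc(Cl)cc1`: 12100 nM

Compound 3 stands highest of the three numbers, the weakest inhibitor of growth in this set. The steps onto it read a 2.0-fold higher number from compound 1 to compound 3 (0.31 log units; beyond the scatter) and a 47-fold higher number from compound 2 to compound 3 (1.67 log units; beyond the scatter); both changes sit on the same aromatic carbon as the one now in question. The remaining step, a 23-fold lower number from compound 1 to compound 2 (1.36 log units; beyond the scatter), shows how much that position can move the number.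

Compound 4 `O=C(NOCc1ccccc1F)c1cn(-c2ccccc2)nc1-c1ccc(F)cc1` is the next candidate. The change from compound 3 is fluoro in place of chloro on an aromatic carbon. For the measured compounds named here, no measured step involves fluoro anywhere, so the expectation rests on the two steps that touch this carbon. Hydrogen to chloro gave a modest rise; methyl to chloro gave a large rise. A halogen exchange at this carbon is a smaller alteration than either of these, and there is nothing in the data to suggest a move as large as a 47-fold higher number from compound 2 to compound 3 (1.67 log units; beyond the scatter). The estimated outcome is a small step, most likely toward the value of compound 1, at the edge of the usual scatter: a 1.5-fold lower number from compound 3 to compound 4 (0.18 log units; within the scatter) is the expected step.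

For compound 4 the expected value in this assay is 8000 nM, with a range from 3000 nM to 20000 nM.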

Compound 4, concentration for 50% growth inhibition: 17500 nM
Compound 4: the middle estimate sits 2.2-fold (0.34 log units) below what was measured; the range from low to high includes it.
By their numbers in this assay, from the lowest: compound 2; then compound 1; then compounds 3 and 4 (each within the scatter of the next).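

In this assay, for the compounds shown here, the change from 4-chlorophenyl to 4-fluorophenyl is the first exchange of one halogen for another at this position, and a 1.4-fold higher number from compound 3 to compound 4 (0.16 log units; within the scatter) gives no separation between the two halogens. Set against hydrogen, fluoro reads a 2.9-fold higher number from compound 1 to compound 4 (0.47 log units; beyond the scatter) and so lies on the same side as chloro, while the step from methyl reads a 67-fold higher number from compound 2 to compound 4 (1.83 log units; beyond the scatter) and leaves compound 2 apart from both halogen compounds, the only one of the four whose substituent lowers the number relative to compound 1. No measurement at hand bears on what separates methyl from the two halogens at this carbon.

With methyl as the only non-halogen group at this carbon, the compounds shown leave open whether the low number of compound 2 is particular to methyl or also extends to ethyl, methoxy, trifluoromethyl or an amine in the same place. On these data alone, the fluorobenzyl group and the unsubstituted phenyl on the core stay the same in all four compounds, so it also remains open whether the large step seen with methyl would persist if either of them were replaced.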